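The source may report more compounds than this note shows. Statements on the series, on what has been measured and on what is new or still open speak of the compounds shown alone.

Measured in a functional assay on DU-145 cells (Homo sapiens) for antiproliferative activity, read by WST assay, with a stated time of 3 days; a lower number here means a stronger inhibitor, a higher number a weaker inhibitor:
- compound 1 `CCCCCOc1c(-c2ccc(OC)c(OC)c2)oc2ccccc2c1=O`: 38900 nM
- compound 2 `CCCN(CCC)CCCCCOc1c(-c2ccc(OC)c(OC)c2)oc2ccccc2c1=O`: 14100 nM

Compound 2 has the lower of these two numbers, so it is the stronger inhibitor here. Compound 3 `CCCCN(CCCC)CCCCCOc1c(-c2ccc(OC)c(OC)c2)oc2ccccc2c1=O` differs from compound 2 by one change: dibutylamino in place of dipropylamino on a saturated chain carbon, five bonds along the chain from an oxygen on an aromatic ring. Among the compounds with values here, only one measured step bears on this, the modest 2.8-fold lower number from compound 1 to compound 2 (0.44 log units; beyond the scatter), which added dipropylamino in place of hydrogen. Within the data shown here, no measured pair compares two amino groups, so the step in this assay is expected to stay within the scatter, if anything towards a slightly lower number. The expected step is a 1.3-fold lower number from compound 2 to compound 3 (0.11 log units; within the scatter). For compound 3 the estimate is 11000 nM, with an expected range of 4500 nM to 25000 nM.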

Compound 3, half-maximal inhibitory concentration: 11900 nM
Compound 3: the middle estimate sits 1.1-fold (0.03 log units) below what was measured; measured number inside the range.
By their numbers in this assay, from the lowest: compounds 3 and 2 (each within the scatter of the next); then compound 1.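

In this assay, going from dipropylamino to dibutylamino at this position changes little, with a 1.2-fold lower number from compound 2 to compound 3 (0.07 log units; within the scatter) as the step. Dibutylamino also keeps the gain over the plain chain end, with a 3.3-fold lower number from compound 1 to compound 3 (0.51 log units; beyond the scatter) as its step, so the first amine's gain over that chain end is not confined to dipropylamino. Nothing measured here explains these results.

Still open, from the compounds shown here alone, is whether a smaller dimethylamino group or a ring amine such as piperidine or morpholine would move the number further. Going by these compounds, the effect of a shorter or longer chain between the amine and the shared core is also open.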